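Notes on a Reductase Series: Compound 3 to Compound 4

The source may report more compounds than this note shows. Statements on the series, on what has been measured and on what is new or still open speak of the compounds shown alone.

Compound 1 `CC[C@H](C)C(=O)O[C@H]1C[C@@H](C)C=C2C=C[C@H](C)[C@H](CC[C@@H]3C[C@@H](O)CC(=O)O3)[C@]21C` and compound 2 `CC[C@H](C)C(=O)O[C@H]1C[C@H](O)C=C2C=C[C@H](C)[C@H](CCC(O)C[C@H](O)CC(=O)O)[C@]21C` belong to one structural family, while compound 3 `COc1ccc(-c2nc(C(F)(F)F)n(CC[C@@H](O)C[C@@H](O)CC(=O)O)c2-c2ccc(F)cc2)cc1` and the not yet measured compound 4 `O=C(O)C[C@H](O)C[C@H](O)CCn1c(C(F)(F)F)nc(-c2cccnc2)c1-c1ccc(F)cc1` carry a 6-carboxy-3,5-dihydroxyhexyl chain on a five-membered aromatic ring with two nitrogen atoms.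

In an assay on microsomes from liver for inhibition of 3-hydroxy-3-methylglutaryl-coenzyme A reductase (Rattus norvegicus) (on this read-out lower numbers stand for stronger inhibition and higher numbers for weaker inhibition), compound 1 gives 3 nM. Compound 2 gives 5 nM in this assay. Compound 3 gives 68 nM, the highest of the three numbers; its gaps to compound 2 and to compound 1 both lie beyond the scatter, so compound 3 is the weakest inhibitor of the measured set.

Compound 4 differs from compound 3 in one place: pyridin-3-yl in place of 4-methoxyphenyl on an aromatic carbon.

Going by the values given here, no pair of measured compounds isolates this exchange, so nothing in the measured set shows what it does to this assay. The expectation rests on compound 3 alone, whose value is 68 nM. The step from compound 3 to compound 4 is expected to be modest, a 1.4-fold lower number from compound 3 to compound 4 (0.13 log units; within the scatter), of uncertain direction and quite possibly not beyond the scatter. Compound 4 is therefore expected at 50 nM, within a range from 15 nM to 160 nM.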

Compound 4, half-maximal inhibitory concentration: 66 nM
Compound 4: middle estimate off by 1.3-fold (0.12 log units), on the low side; low and high end bracket the measured number.
By their numbers in this assay, from the lowest: compounds 1 and 2 (each within the scatter of the next); then compounds 4 and 3 (each within the scatter of the next).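

The exchange at this carbon, on the five-membered aromatic ring, gives a 1.0-fold lower number from compound 3 to compound 4 (0.01 log units; within the scatter) in this assay and so leaves the two compounds indistinguishable on this read-out. Going by these compounds alone, this is the first direct reading at this position: a six-membered aromatic ring of carbon only carrying a methoxy group, 8 heavy atoms in all, and pyridin-3-yl, with 6 heavy atoms and 1 hetero atom in the ring, are interchangeable here on the shared core. Both groups count 1 hydrogen-bond acceptor, so the pair does not show what the loss of an acceptor at this position would do, and nothing at hand gives a reason for the equal readings.

Still open, on these data alone, is whether the position accepts groups of another kind, such as a saturated cyclohexyl ring, a primary amine or a carboxylic acid, in place of an aromatic ring. Also open, as far as these compounds go, is whether pyridin-3-yl behaves in the same way when a methyl group or a chlorine atom stands where the trifluoromethyl group now sits.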